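This account rests on a few compounds, and the source may have more. Where it says the series, first, only, none or still open, it means among the compounds named here.

In an ADME assay on cells (Fibroblast, Homo sapiens) for inhibition, read by MTT assay, with a stated time of 24 h (a lower number here means a stronger inhibitor, a higher number a weaker inhibitor), the series sits entirely at its limit, as the limit of > 200000 nM in this assay, at which 3 of the 3 values shown sit, shows. Compound 1 (`Nc1ccc(C(=O)N/N=C/c2ccc3c(c2)no[n+]3[O-])cc1`) gives > 200000 nM, which is a limit and not a number. Compound 2 (`CCCOc1ccc(C(=O)N/N=C/c2ccc3c(c2)no[n+]3[O-])cc1`) gives > 200000 nM, which is also only a limit. Compound 3 (`CC(C)c1ccc(C(=O)N/N=C/c2ccc3c(c2)no[n+]3[O-])cc1`) gives > 200000 nM, again a limit.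

Compound 4 (`O=C(N/N=C/c1ccc2c(c1)no[n+]2[O-])c1ccc(I)cc1`) carries iodo in place of propoxy on an aromatic carbon, para to a large group: iodo in place of propoxy on an aromatic carbon.

The measured steps that bear on this change swap the group at the same place. They are a step that the two limits leave unreadable from compound 1 to compound 2, a step that the two limits leave unreadable from compound 1 to compound 3 and a step that the two limits leave unreadable from compound 2 to compound 3. None has a readable size, so they give no measured effect of this group, only the fact that amino, propoxy and isopropyl all end at the same limit in this assay. On that basis, no change beyond the scatter is expected, and a further limit is the likeliest report. The expected outcome is a number no higher from compound 2 to compound 4 (the limit leaves the size open). For compound 4 the estimated value is 200000 nM, with an expected range from 80000 nM to 400000 nM.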

Compound 4, half-maximal inhibitory concentration: > 200000 nM
Compound 4 was reported as a limit (the forecaster's own chance of this, stated with the estimate: 75%); the middle value lies on the limit itself.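

Compound 4 ends at the same limit as compounds 1, 2 and 3, so no new step from it to any of them can be read in this assay: the limit of > 200000 nM in this assay, at which 4 of the 4 values shown sit.

The compounds shown leave open whether any group at this place gives a measurable value.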